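Aryl for benzyl on the cyanoguanidine of a cromakalim-type core

The source may hold more compounds than are shown below. What is called first, only, known or untested is meant among the compounds shown, and "the series" means these compounds.

Measured compounds:
compound 1, `CC1(C)Oc2ccc(C#N)cc2[C@@H](NC(=O)Nc2ccccc2)[C@@H]1O`, 800 nM
compound 2, `CC1(C)Oc2ccc(C#N)cc2[C@@H](/N=C(\NC#N)NCc2ccccc2)[C@@H]1O`, 2400 nM
compound 3, `CC1(C)Oc2ccc(C#N)cc2[C@@H](n2c(O)nc3ccccc32)[C@@H]1O`, 41000 nM

Three compounds share the same core and differ only in the group carried on the benzylic nitrogen. In a functional assay (aorta) with Rattus norvegicus as the target (a higher number here means a weaker inhibitor, a lower number a stronger inhibitor), compound 1 gives 800 nM, compound 2 gives 2400 nM and compound 3 gives 41000 nM. Compound 2 thus stands second highest of the three numbers: its number is higher than that of compound 1 by a step beyond the scatter, and lower than that of compound 3 by a much larger gap.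

Compound 4, `CSc1cccc(N/C(=N/[C@@H]2c3cc(C#N)ccc3OC(C)(C)[C@H]2O)NC#N)c1`, is not yet measured. It differs from compound 2 in one place: 3-(methylsulfanyl)phenyl in place of benzyl on an amine nitrogen. For the measured compounds named here, no step between measured compounds covers this change, so the expectation rests on compound 1 and compound 2 alone, where the aryl group attached directly to the nitrogen of the urea goes with a lower number than the benzyl group on the cyanoguanidine. Compound 4 is therefore expected to land somewhat below compound 2 in this assay, by a step of a 2.4-fold lower number from compound 2 to compound 4 (0.38 log units; beyond the scatter), though a result within the scatter would not surprise. The estimate for compound 4 is 1000 nM, with a range from 300 nM to 4000 nM.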

Compound 4, half-maximal inhibitory concentration: 1400 nM
Estimate against measurement, compound 4: 1.4-fold (0.15 log units) below, and the stated range covers the measured number.
By their numbers in this assay, from the lowest: compounds 1, 4 and 2 (each within the scatter of the next, the first and the last beyond it); then compound 3.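

In this assay the change from benzyl to 3-(methylsulfanyl)phenyl on the amine nitrogen gives a 1.7-fold lower number from compound 2 to compound 4 (0.23 log units; within the scatter), so compound 2 and compound 4 cannot be told apart on this read-out. For the compounds shown here, this is the first comparison in the set that changes only this group while the cyanoguanidine stays in place, and it shows that this position accepts an aromatic ring bound directly to the nitrogen, in place of benzyl, with no change beyond the scatter, even with the methylsulfanyl group added to that ring. No measurement at hand accounts for this result.

Since two things change at once in this step, the loss of the benzyl carbon link and the arrival of the methylsulfanyl group, the compounds shown leave the share of each open, and a plain phenyl group on this nitrogen would be needed to separate them. Also open, on these data alone, is how the position responds to a longer chain such as 2-phenylethyl, or to a methoxy group or a chlorine atom in place of the methylsulfanyl group on the ring.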